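The source may report more compounds than this note shows. Statements on the series, on what has been measured and on what is new or still open speak of the compounds shown alone.

Measured in an ADME assay on L6 cells (Rattus norvegicus) for cytotoxicity, with a stated time of 72 h; a higher number here means a weaker inhibitor, a lower number a stronger inhibitor:
Compound 1 `CCN(CC)CC(=O)OC1CC2(N(C)C)CC(c3ccccc3)C1C(c1ccccc1)C2`: 30100 nM
Compound 2 `CC(C)(C)C(=O)OC1CC2(N3CCCC3)CC(c3ccccc3)C1C(c1ccccc1)C2`: 7620 nM
Compound 3 `CN(C)C12CC(OC(=O)/C=C/c3ccccc3)C(C(c3ccccc3)C1)C(c1ccccc1)C2`: 3820 nM

Compound 3 and compound 2 lie within the scatter of each other. Going by the values given here, the one measured step shows a 7.9-fold lower number from compound 1 to compound 3 (0.90 log units; beyond the scatter). Compound 4 `O=C(/C=C/c1ccccc1)OC1CC2(N3CCCC3)CC(c3ccccc3)C1C(c1ccccc1)C2` keeps the ((2-phenylethenyl)carbonyl)oxy group of compound 3 and differs elsewhere: pyrrolidin-1-yl in place of dimethylamino on a saturated ring carbon. That measured step concerns the group on the carbonyl carbon, so it sets no size for this change. Among the compounds with values here, compound 2 carries pyrrolidin-1-yl, but no measured pair isolates the swap. In this assay, no step beyond the scatter is therefore expected. The expected outcome is a 1.3-fold lower number from compound 3 to compound 4 (0.10 log units; within the scatter). For compound 4 the estimate is 3000 nM, with an expected range of 1200 nM to 7500 nM.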

Compound 4, half-maximal inhibitory concentration: 3500 nM
Beside the measured number, compound 4's estimate is 1.2-fold (0.07 log units) below it; measured number inside the range.
By their numbers in this assay, from the lowest: compounds 4, 3 and 2 (each within the scatter of the next, the first and the last beyond it); then compound 1.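

In this assay pyrrolidin-1-yl in place of dimethylamino on the saturated ring carbon gives a 1.1-fold lower number from compound 3 to compound 4 (0.04 log units; within the scatter) while the ((2-phenylethenyl)carbonyl)oxy group stays fixed, so this swap alone does not separate the two compounds. With pyrrolidin-1-yl fixed, 2-phenylethenyl in place of tert-butyl on the carbonyl carbon gives a 2.2-fold lower number from compound 2 to compound 4 (0.34 log units; beyond the scatter) and thus runs in the same direction as a 7.9-fold lower number from compound 1 to compound 3 (0.90 log units; beyond the scatter) at that carbon. Nothing available explains either step.

On these data alone, whether the swap stays this small with tert-butyl or (diethylamino)methyl on the carbonyl carbon remains open. So does how piperidin-1-yl or morpholin-4-yl would read on the same ring carbon.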